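From 1H-imidazol-1-yl to dimethylamino: estimating a cytotoxicity step

The source may hold more compounds than are shown below. What is called first, only, known or untested is meant among the compounds shown, and "the series" means these compounds.

Going by the values given here, in a functional assay on HCT-15 cells (Homo sapiens) for cytotoxicity (on this read-out higher numbers stand for weaker inhibition and lower numbers for stronger inhibition), compound 2 `Cc1nn(C)c(-n2ccnc2)c1/C=N/OCc1ccc(C(=O)OC(C)(C)C)cc1` gives 8.67 ug/mL, the higher of the two numbers so far and therefore the weaker inhibition. Among the compounds with values here, its only measured neighbour, compound 1 `Cc1nn(C)c(N2CCCC2)c1/C=N/OCc1ccc(C(=O)OC(C)(C)C)cc1`, gives 0.1 ug/mL. The unmeasured compound 3 `Cc1nn(C)c(N(C)C)c1/C=N/OCc1ccc(C(=O)OC(C)(C)C)cc1` keeps the shared core and has dimethylamino in place of 1H-imidazol-1-yl on an aromatic carbon. Within the data shown here, the one measured step that bears on this is an 87-fold higher number from compound 1 to compound 2 (1.94 log units; beyond the scatter), which is large and beyond the scatter. Dimethylamino, like the pyrrolidin-1-yl of compound 1 at 0.1 ug/mL, carries no aromatic ring, so a large step towards a lower number is expected in this assay, though a single pair offers thin support. The expected change is a 22-fold lower number from compound 2 to compound 3 (1.34 log units; beyond the scatter). For compound 3 the estimated value is 0.4 ug/mL, with a range of 0.06 ug/mL to 3 ug/mL.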

Compound 3, half-maximal inhibitory concentration: 6.22 ug/mL
Beside the measured number, compound 3's estimate is 16-fold (1.19 log units) below it; the measured number lies above the stated range.
By their numbers in this assay, from the lowest: compound 1; then compounds 3 and 2 (each within the scatter of the next).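

In this assay the change to dimethylamino gives a 1.4-fold lower number from compound 2 to compound 3 (0.14 log units; within the scatter) and so leaves the two compounds indistinguishable. Removing the aromatic ring is therefore not enough at this position: dimethylamino carries no ring at all, and the comparison with pyrrolidin-1-yl reads a 62-fold higher number from compound 1 to compound 3 (1.79 log units; beyond the scatter), which is a large step. Among these three compounds, only compound 1 stands apart, while an aromatic ring and an open dimethylamino group give numbers that cannot be separated.

No measurement at hand explains this gap. From the compounds shown here alone, it also remains open whether the closed saturated ring of pyrrolidin-1-yl is what matters, or its two extra carbons; piperidin-1-yl and diethylamino at the same place would help to separate these two readings.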